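Benzoyl for Trifluoromethyl: Expected Solubility of Compound 4

The source may hold more compounds than are shown below. What is called first, only, known or untested is meant among the compounds shown, and "the series" means these compounds.

Compound 1 `O=C(Nc1ccc(C(F)(F)F)cc1)c1cc(Br)ccc1O` and compound 2 `O=C(c1ccccc1)c1ccc(NC(=O)c2cc(Br)ccc2O)cc1` share one core; compound 3 `O=C(NCCCCl)Oc1ccc(Cl)cc1C(=O)Nc1ccc(C(F)(F)F)cc1` and compound 4 `O=C(NCCCCl)Oc1ccc(Cl)cc1C(=O)Nc1ccc(C(=O)c2ccccc2)cc1` share another, and the difference between the two cores is not broken down here. In a physicochemical assay for solubility, read by spectrophotometry (a higher number here means a more soluble compound, a lower number a less soluble compound), compound 1 gives only a limit, < 100000 nM. Compound 2 likewise gives only a limit in this assay, < 50000 nM. The change from compound 1 to compound 2 is benzoyl in place of trifluoromethyl on an aromatic carbon, and the step that the two limits leave unreadable from compound 1 to compound 2 cannot be read from two limits. Compound 3 also gives only a limit in this assay, < 50000 nM. The change from compound 3 to compound 4 is benzoyl in place of trifluoromethyl on an aromatic carbon, the same change as before. Because the limit of < 100000 nM in this assay, at which 1 of the 3 values shown sits, and the limit of < 50000 nM in this assay, at which 2 of the 3 values shown sit, show every measured value sitting at a limit, no size is known for this change, and compound 4 is expected to sit at a limit as well, with an expected step that the limit leaves unreadable from compound 3 to compound 4. Compound 4 is therefore estimated at 10000 nM.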

Compound 4, solubility: < 50000 nM
Compound 4: no number, only a limit (the forecaster's own chance of this, stated with the estimate: 80%); the middle value is on the limit's open side.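

Compound 3 and compound 4 each give only a limit, not a number, and no step can be read between them. The compounds shown leave open the size and direction of any solubility difference between trifluoromethyl and benzoyl.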